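Cytotoxicity notes on a thiophene-methylamine series: cyclopentyl for propyl

This account rests on a few compounds, and the source may have more. Where it says the series, first, only, none or still open, it means among the compounds named here.

Compound 1 `CCCc1csc(CN[C@@H]2C[C@H]3C[C@@H]([C@H]2C)C3(C)C)c1` is the reference. In an ADME assay on MDCK cells (Canis lupus familiaris) for cytotoxicity, read by microscopy, with a stated time of 48 h (a lower number here means that less compound is tolerated, a higher number that more compound is tolerated), compound 1 gives 12500 nM, the lowest of the three numbers in hand. Compound 3 `C[C@H]1[C@H](NCc2sccc2C2CC2)C[C@H]2C[C@@H]1C2(C)C` gives 25000 nM, a value within the scatter of compound 1. Compound 2 `C[C@H]1[C@H](NCc2ccc(Br)s2)C[C@H]2C[C@@H]1C2(C)C` gives 43000 nM, which lies beyond the scatter above compound 1. For the measured compounds named here, no step between measured compounds that differ in a single place is available, so no measured step guides the change.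

Compound 4 `C[C@H]1[C@H](NCc2cc(C3CCCC3)cs2)C[C@H]2C[C@@H]1C2(C)C` differs from compound 1 by one change: cyclopentyl in place of propyl on an aromatic carbon. For compound 4 the expected step is a 1.3-fold lower number from compound 1 to compound 4 (0.10 log units; within the scatter), which is not expected to exceed the scatter. Compound 4 is expected to give 10000 nM, within 4000 nM to 25000 nM.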

Compound 4, minimum cytotoxic concentration: 1560 nM
The estimate for compound 4 lay 6.4-fold (0.81 log units) above the measured number; the whole stated range lies above it.
By their numbers in this assay, from the lowest: compound 4; then compounds 1, 3 and 2 (each within the scatter of the next, the first and the last beyond it).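

For the compounds shown here, at this aromatic carbon, two ring bonds from the ring sulfur, the step in this assay is the first single-place comparison: cyclopentyl in place of propyl gives an 8.0-fold lower number from compound 1 to compound 4 (0.90 log units; beyond the scatter). The position is therefore sensitive to the change, although neither group carries hydrogen-bond donors, acceptors or net charge. Nothing measured bears on why the step is this large. From the compounds shown here alone, whether the ring itself or the larger carbon count goes with the lower number remains open; a pentyl chain or a cyclohexyl ring at this carbon would separate the two.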